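The source may hold more compounds than are shown below. What is called first, only, known or untested is meant among the compounds shown, and "the series" means these compounds.

Measured compounds:
compound 1 `CC(C)Cn1ccc(N2CCC(c3ccccc3)CC2)c(C#N)c1=O` — 282 nM
compound 2 `N#Cc1c(N2CCC(c3ccccc3)CC2)ccn(CC2CC2)c1=O` — 151 nM
compound 3 `N#Cc1c(N2CCC(c3cccc(F)c3)CC2)ccn(CC2CC2)c1=O` — 141 nM

In a functional assay on CHO cells for positive allosteric modulation of metabotropic glutamate receptor 2 (Homo sapiens), with a stated time of 30 min (on this read-out lower numbers stand for an effect already at smaller amounts and higher numbers for an effect only at larger amounts of compound), compound 3 sits within the scatter of both compound 2 and compound 1; its step of a 1.1-fold lower number from compound 2 to compound 3 (0.03 log units; within the scatter) and the earlier step of a 1.9-fold lower number from compound 1 to compound 2 (0.27 log units; within the scatter) both fall within the usual spread, so no ordering among the three is claimed. Compound 4 `N#Cc1c(N2CCC(c3ccccc3Cl)CC2)ccn(CC2CC2)c1=O` differs from compound 3 by 2-chlorophenyl in place of 3-fluorophenyl on a saturated ring carbon. Among the measured compounds shown here, only the step from compound 2 to compound 3 touches the same phenyl ring, and it was within the scatter; no measured step shows a halogen moved to another ring carbon or chlorine in place of fluorine. Compound 4 is therefore expected to show no step beyond the scatter in this assay, the estimated step being a 1.4-fold higher number from compound 3 to compound 4 (0.15 log units; within the scatter). Compound 4 is estimated at 200 nM, with a range from 60 nM to 700 nM.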

Compound 4, half-maximal effective concentration: 49 nM
Estimate against measurement, compound 4: 4.1-fold (0.61 log units) above, outside the stated range (below it).
By their numbers in this assay, from the lowest: compound 4; then compounds 3, 2 and 1 (each within the scatter of the next).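

In this assay, a change on the phenyl ring now gives a step beyond the scatter: chloro in place of hydrogen gives a 3.1-fold lower number from compound 2 to compound 4 (0.49 log units; beyond the scatter), whereas fluoro in place of hydrogen in compound 3 stayed within the scatter of compound 2. 2-chlorophenyl in place of 3-fluorophenyl likewise gives a 2.9-fold lower number from compound 3 to compound 4 (0.46 log units; beyond the scatter), though this swap alters both the halogen and its ring carbon. Nothing available here accounts for the gain.

The compounds shown leave open whether the gain follows chlorine or its ring carbon, which 2-fluorophenyl and 3-chlorophenyl would separate. On these data alone, whether 2-methylphenyl would match 2-chlorophenyl also remains open.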